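Working notes: compound 3 as a variant of compound 1

The source may report more compounds than this note shows. Statements on the series, on what has been measured and on what is new or still open speak of the compounds shown alone.

compound 1 `Cc1cc(O)c(C2=NN(c3ccc(S(N)(=O)=O)cc3)C(c3ccccc3O)C2)cc1Cl` — 2390 nM
compound 2 `Cc1cc(O)c(C2=NN(c3ccc(S(N)(=O)=O)cc3)C(c3ccccc3Cl)C2)cc1Cl` — 2970 nM

In a functional assay on RPMI-8226 cells (Homo sapiens) for antiproliferative activity, with a stated time of 48 h (a higher number here means a weaker inhibitor of growth, a lower number a stronger inhibitor of growth), compound 1 gives 2390 nM, the lower of the two numbers shown; compound 2 gives 2970 nM, and the step of a 1.2-fold higher number from compound 1 to compound 2 (0.09 log units; within the scatter) lies within the scatter. Compound 3 `COc1ccc(C2CC(c3cc(Cl)c(C)cc3O)=NN2c2ccc(S(N)(=O)=O)cc2)c(OC)c1OC` differs from compound 1 by 2,3,4-trimethoxyphenyl in place of 2-hydroxyphenyl on a saturated ring carbon. Among the compounds with values here, the one measured step, from compound 1 to compound 2, alters the same saturated ring carbon's aryl group only slightly and moved nothing beyond the scatter; it bears on this change only loosely, and no measured step covers a trimethoxyphenyl entry. Compound 3 is therefore expected to show a 1.0-fold higher number from compound 1 to compound 3 (0.00 log units; within the scatter), with a widened range: the estimate is 2400 nM, between 900 nM and 6500 nM.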

Compound 3, concentration for 50% growth inhibition: 2660 nM
For compound 3 the middle estimate is 1.1-fold (0.04 log units) below the measured one, within the range that was stated.
By their numbers in this assay, from the lowest: compounds 1, 3 and 2 (each within the scatter of the next).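

In this assay, 2,3,4-trimethoxyphenyl on the saturated ring carbon gives a 1.1-fold higher number from compound 1 to compound 3 (0.05 log units; within the scatter) and a 1.1-fold lower number from compound 2 to compound 3 (0.05 log units; within the scatter). This carbon therefore accepts an aryl group with more heavy atoms and no hydrogen-bond donor without a step beyond the scatter, which the exchange between 2-hydroxyphenyl and 2-chlorophenyl did not show. No measured data bear on this result.

From the compounds shown here alone, all three compounds carry an aryl group here, so an amine, a carboxylic acid or a longer alkyl chain at this carbon remains open. Going by these compounds, the 5-chloro-2-hydroxy-4-methylphenyl and 4-sulfamoylphenyl groups stay constant, so whether these small steps persist with either group replaced is also open.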